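Furan-2-yl for 3,4-dimethoxyphenyl: compound 4

The compounds below may be only part of what the source reports. "The series", "measured", "known", "first", "only" and "open" are said of these compounds alone.

Of the compounds shown here, three have been read in a functional assay on HCT-116 cells (Homo sapiens) for inhibition, read by sulforhodamine B assay, with a stated time of 48 h, tested at 50 uM (a lower number here means less inhibition of growth, a higher number more inhibition of growth at the concentration tested), so far. Compound 2 `COc1ccc(/C=C/C(=O)/C=C/c2ccc(OCc3cn(CCCCOc4cc(=O)oc5ccccc45)nn3)c(OC)c2)cc1OC` stands second at 55% in this small set, under compound 1 `COc1cc(/C=C/C(=O)/C=C/c2cccc3ccccc23)ccc1OCc1cn(CCOc2cc(=O)oc3ccccc23)nn1` at 83%, while compound 3 `COc1ccc(/C=C/C(=O)/C=C/c2ccc(OCc3cn(CCCCCOc4cc(=O)oc5ccccc45)nn3)c(OC)c2)cc1` gives 35% in the same test, with both gaps beyond the scatter. Compound 4 `COc1cc(/C=C/C(=O)/C=C/c2ccco2)ccc1OCc1cn(CCCCOc2cc(=O)oc3ccccc23)nn1` carries furan-2-yl in place of 3,4-dimethoxyphenyl on a double-bonded chain carbon bound to a double-bonded chain carbon and is otherwise the same as compound 2. The measured compounds differ from one another in more than one place, so none of them isolates this change. In this assay a small upward step within the scatter is expected, estimated as a number 5 percentage points higher from compound 2 to compound 4 (within the scatter) and no larger. For compound 4 the expected growth inhibition is 60% with an estimated range from 35% to 80% at the concentration tested.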

Compound 4, percent growth inhibition at one concentration: 47%
Compound 4: middle estimate off by 13 percentage points, on the high side; measured number inside the range.
By their numbers in this assay, from the lowest: compound 3; then compounds 4 and 2 (each within the scatter of the next); then compound 1.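

With furan-2-yl in place of 3,4-dimethoxyphenyl on a double-bonded chain carbon bound to a double-bonded chain carbon, this assay gives the series its first one-place comparison: a number 8 percentage points lower from compound 2 to compound 4 (within the scatter). At this place, the aromatic ring can thus go from 10 heavy atoms to 5 with no step beyond the scatter. Nothing available explains this result. 

Still open, on these data alone, is whether a pyridin-3-yl or 4-carboxyphenyl group at this place would step beyond the scatter. Also open, as far as these compounds go, is whether the furan-2-yl result carries over to a longer chain on the triazole nitrogen.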